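The compounds below may be only part of what the source reports. "The series", "measured", "known", "first", "only" and "open" are said of these compounds alone.

Measured in a toxicity assay on HeLa cells (Homo sapiens) for cytotoxicity; on this read-out lower numbers stand for higher toxicity in this test and higher numbers for lower toxicity in this test:
Compound 1 `COc1ncc(-c2ccccc2)cc1[C@@H](c1ccccc1)[C@@](O)(CCN(C)C)c1cc(F)ccc1F`: "nd" (no result reported)
Compound 2 `COc1nc(-c2ccncc2)ccc1[C@@H](c1ccccc1)[C@@](O)(CCN(C)C)c1cccc2ccccc12`: 9.6 ug/mL
Compound 3 `COc1nc(-c2ccc(F)cc2)ccc1[C@@H](c1ccccc1)[C@@](O)(CCN(C)C)c1cccc2ccccc12`: > 64 ug/mL

As far as these compounds go, compound 1 has no number to start from, so its place on the scale is unknown. Compound 4 `COc1ncc(-c2ccccc2)cc1[C@@H](c1ccccc1)[C@@](O)(CCN(C)C)c1ccccc1` differs from it by one change: phenyl in place of 2,5-difluorophenyl on a saturated chain carbon bound to an oxygen on a saturated carbon and two saturated chain carbons. Within the data shown here, the only measured step, an at least 6.6-fold higher number from compound 2 to compound 3 (0.82 log units; beyond the scatter), is 4-fluorophenyl in place of pyridin-4-yl on an aromatic carbon. It lies beyond the scatter, but it concerns another group and another pair of compounds, so it gives no size or direction for the loss of the two fluorines. Among the measured compounds shown here, no step from compound 1 can therefore be expected in this assay. The estimate has to rest on the nearest values instead. Like compound 4, compound 3 carries no pyridin-4-yl group, and compound 3 gives > 64 ug/mL, which is a limit of the assay. A high number therefore seems more likely than one near the pyridine-bearing compound 2 at 9.6 ug/mL. For compound 4 the expected value is 40 ug/mL, with an estimated range from 14 ug/mL to 64 ug/mL.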

Compound 4, half-maximal cytotoxic concentration: 11.9 ug/mL
Beside the measured number, compound 4's estimate is 3.4-fold (0.53 log units) above it; measured number below the stated range.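

In this assay, among these compounds, compound 1 stands at "nd" (no result reported), so no step from compound 1 to compound 4 can be read. The compounds shown leave open how phenyl in place of 2,5-difluorophenyl changes the number in this assay.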